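Methyl to diethylcarbamoyl on the shared core

A few compounds are considered here, and "the series" means these few. Any claim that something is new, unique, unknown or untested is made for them only; others in the source may bear on it.

Of the compounds shown here, three on the shared core have been measured. In a functional assay on HCT-116 cells (Homo sapiens) for antiproliferative activity (on this read-out higher numbers stand for weaker inhibition and lower numbers for stronger inhibition), compound 1 `Cc1cccc2[nH]c(-c3n[nH]c4ncc(-c5cncc6ccccc56)cc34)nc12` gives 1640 nM, the highest of the three numbers. Compound 2 `COCc1cccc2[nH]c(-c3n[nH]c4ncc(-c5ccncc5)cc34)nc12` gives 62 nM, and compound 3 `COCc1cccc2[nH]c(-c3n[nH]c4ncc(-c5cncnc5)cc34)nc12` gives 330 nM. Among the compounds with values here, the only single-point step, a 5.3-fold higher number from compound 2 to compound 3 (0.73 log units; beyond the scatter), concerns a different part of the molecule and does not touch the position altered here. Compound 4 `CCN(CC)C(=O)c1cccc2[nH]c(-c3n[nH]c4ncc(-c5cncc6ccccc56)cc34)nc12` differs from compound 1 by diethylcarbamoyl in place of methyl on an aromatic carbon. Within the data shown here, no measured step bears on this change; compounds 2 and 3 differ from compound 1 in two places at once, so their lower numbers cannot be assigned to the substituent exchanged here. Among the measured compounds shown here, with no precedent, the step of a 1.6-fold lower number from compound 1 to compound 4 (0.21 log units; within the scatter) in this assay is expected to be small, with a wide range. Compound 4 is estimated at 1000 nM, between 250 nM and 4000 nM.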

Compound 4, half-maximal inhibitory concentration: 55 nM
Beside the measured number, compound 4's estimate is 18-fold (1.26 log units) above it; the measured number lies below the stated range.
By their numbers in this assay, from the lowest: compounds 4 and 2 (each within the scatter of the next); then compound 3; then compound 1.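

In this assay, within the data shown here, diethylcarbamoyl in place of methyl on an aromatic carbon gives a 30-fold lower number from compound 1 to compound 4 (1.47 log units; beyond the scatter), the first measured step at this position. The position therefore accepts a much larger group than methyl, and the exchange strongly affects the read-out on the core of compound 1. No evidence at hand gives a cause for this step.

Still open, as far as these compounds go, is whether the carbonyl or the two ethyl groups carry the step. A primary carboxamide, a dimethylcarbamoyl group or a carboxylic acid at this carbon would separate these parts.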